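The source may hold more compounds than are shown below. What is called first, only, known or untested is meant among the compounds shown, and "the series" means these compounds.

Compound 1 `CC/C(=N\OC(c1ccc(OCc2ccc3ccccc3n2)cc1)C1CCCCC1)C(=O)O`: 30 nM
Compound 2 `O=C(O)C1CCC(=NOC(c2ccc(OCc3ccc4ccccc4n3)cc2)C2CCCCC2)CC1`: 67 nM
Compound 3 `C=CCC(O/N=C(\C)C(=O)O)c1ccc(OCc2ccc3ccccc3n2)cc1`: 142 nM

Of the compounds shown here, three sharing the same core have been tested in a functional assay for inhibition of Polyunsaturated fatty acid 5-lipoxygenase (Homo sapiens); on this read-out higher numbers stand for weaker inhibition and lower numbers for stronger inhibition. Compound 3 stands highest of the three numbers: compound 2 sits a step below it, and compound 1 a larger step below, so compound 3 is the weakest inhibitor of the set. Compound 4 `C/C(=N\OC(CC1CCCCC1)c1ccc(OCc2ccc3ccccc3n2)cc1)C(=O)O` is the next candidate, and it differs from compound 3 in one place: cyclohexyl in place of vinyl on a saturated chain carbon, two bonds along the chain from an aromatic carbon and an oxygen on an unsaturated carbon. Among the compounds with values here, the only measured step between neighbours, a 2.2-fold higher number from compound 1 to compound 2 (0.35 log units; beyond the scatter), changes the acid-bearing side of the molecule, not the chain carbon that is altered here, so it bears only loosely on the present change. What the two values of compound 1 and compound 3 show is that a cyclohexyl-bearing structure gave the lowest number and the allyl-bearing structure the highest, though those two also differ elsewhere. On that basis compound 4 is expected to give a lower number than compound 3, a step of about a 2.4-fold lower number from compound 3 to compound 4 (0.37 log units; beyond the scatter) in this assay. The estimate for compound 4 in this assay is 60 nM, with a range from 20 nM to 200 nM.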

Compound 4, half-maximal inhibitory concentration: 29 nM
Estimate against measurement, compound 4: 2.1-fold (0.32 log units) above; the measured number falls inside the stated range.
By their numbers in this assay, from the lowest: compounds 4 and 1 (each within the scatter of the next); then compound 2; then compound 3.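

In this assay, putting cyclohexyl in place of vinyl on a saturated chain carbon, two bonds along the chain from an aromatic carbon and an oxygen on an unsaturated carbon, gives a 4.9-fold lower number from compound 3 to compound 4 (0.69 log units; beyond the scatter). Within the data shown here, this is the first direct reading of this position, as the only earlier step, from compound 1 to compound 2, changed the acid-bearing side of the molecule; it shows that the group on this carbon can by itself move the number beyond the scatter, and that a group carrying a six-membered ring of carbon only goes with stronger inhibition here than the allyl group does. Nothing available explains why the number falls with this change.

A single pair cannot separate the effect of adding the ring, losing the double bond or lengthening the group, and a plain propyl chain or a benzyl group on this carbon would be the kind of neighbour needed to pull those apart. As far as these compounds go, whether the same swap would act alike with the acid-bearing side of compound 2 also remains open.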